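Replacing Oxetan-3-yl Where Only Limits Are Known

The source may report more compounds than this note shows. Statements on the series, on what has been measured and on what is new or still open speak of the compounds shown alone.

In a toxicity assay on HT-29 cells (Homo sapiens) for cytotoxicity (on this read-out higher numbers stand for lower toxicity in this test and lower numbers for higher toxicity in this test), compound 3 (`CN1C(=S)[C@@H](NC(=O)c2nc(Cc3ccccc3)n(C3COC3)n2)COc2ccccc21`) gives > 100000 nM as a limit of the assay, not a number. Compound 1 (`CN1C(=S)[C@@H](NC(=O)c2nc(Cc3ccccc3)n(C3CCC3)n2)COc2ccccc21`) gives > 100000 nM as a limit too. Compound 2 (`CN1C(=S)[C@@H](NC(=O)c2nc(Cc3ccccc3)n(C3CCCCCC3)n2)COc2ccccc21`) gives > 100000 nM as a limit too. Within the data shown here, with the limit of > 100000 nM in this assay, at which 3 of the 3 values shown sit, as the only mark, no measured step has a readable size.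

Compound 4 (`CN1C(=S)[C@@H](NC(=O)c2nc(Cc3ccccc3)n(CC3CCOC3)n2)COc2ccccc21`) differs from compound 3 in one place ((oxolan-3-yl)methyl in place of oxetan-3-yl on an aromatic nitrogen): (oxolan-3-yl)methyl in place of oxetan-3-yl on an aromatic nitrogen. Three earlier changes at that same nitrogen bear on it: a step that the two limits leave unreadable from compound 1 to compound 2 and a step that the two limits leave unreadable from compound 1 to compound 3 and a step that the two limits leave unreadable from compound 2 to compound 3 all leave the size open. On that ground no change beyond the scatter is expected in this assay and no direction can be named. The estimated change is a number no higher from compound 3 to compound 4 (the limit leaves the size open) and a limit is expected again. The estimate for compound 4 is 100000 nM with 40000 nM to 200000 nM as its expected range.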

Compound 4, half-maximal cytotoxic concentration: > 100000 nM
Compound 4: a limit, no number; the forecaster's own chance of this, stated with the estimate: 85%; the middle value lies on the limit itself.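

In this assay compound 4 gives a limit and not a number, so its steps to compound 1, compound 2 and compound 3 cannot be read. The compounds shown leave open whether any group on this aromatic nitrogen changes the toxicity at all, because all of them share one mark: the limit of > 100000 nM in this assay, at which 4 of the 4 values shown sit.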